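The source may report more compounds than this note shows. Statements on the series, on what has been measured and on what is new or still open speak of the compounds shown alone.

Measured so far in an assay on cells for inhibition of Amine oxidase [flavin-containing] B (Homo sapiens), read by fluorescence and Amplex Red, with a stated time of 15 min; on this read-out higher numbers stand for weaker inhibition and lower numbers for stronger inhibition:
Compound 1 `Cc1cccc2cc(-c3ccc(Br)cc3)oc12` gives 950 nM.
Compound 2 `Cc1cccc2cc(-c3cccc(Br)c3)oc12` gives 3980 nM.

Within the data shown here, compound 2 holds the highest of the two numbers recorded in this assay, and its only neighbour is compound 1, whose number lies lower by a margin that falls outside the usual scatter. Compound 3 `Cc1cccc2cc(-c3ccccc3)oc12` has not yet been measured. It differs from compound 2 in one place: hydrogen in place of bromo on an aromatic carbon. Among the measured compounds shown here, no step between two measured compounds covers this change, so the expectation rests on the two recorded values and the change itself. Compound 1 and compound 2 together show that a bromo on this ring can go with either a low or a high number in this assay. With the bromo gone, the number for compound 3 is expected to fall somewhat from that of compound 2, or at most to stay within the scatter of it. The expected step from compound 2 to compound 3 is a 1.6-fold lower number from compound 2 to compound 3 (0.20 log units; within the scatter). Compound 3 is therefore estimated at 2500 nM, with a range from 800 nM to 8000 nM.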

Compound 3, half-maximal inhibitory concentration: 10700 nM
Compound 3: the middle estimate sits 4.3-fold (0.63 log units) below what was measured; measured number above the stated range.
By their numbers in this assay, from the lowest: compound 1; then compound 2; then compound 3.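

In this assay the change to hydrogen on the aromatic carbon meta to a large group is not neutral: it gives a 2.7-fold higher number from compound 2 to compound 3 (0.43 log units; beyond the scatter) and so shows that the bromo at this place goes with the lower number, even though compound 2 is the higher of the two bromo compounds. The same change starting from compound 1 gives an 11-fold higher number from compound 1 to compound 3 (1.05 log units; beyond the scatter) and is the larger of the two steps, so the bromo counts for more in compound 1 than in compound 2, and among the three compounds none goes against the link between bromo and a lower number. No measurement on hand bears on the reason for these steps.

From the compounds shown here alone, whether this effect belongs to the bromo itself or would also come with a chloro, a methyl or a methoxy on the same ring stays open. Also open, going by these compounds, is how an amine or a carboxylic acid on this ring would read in this assay and whether a change to the methyl on the shared core would leave these steps as they are.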